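Swapping methoxy for chloro in a series

The source may report more compounds than this note shows. Statements on the series, on what has been measured and on what is new or still open speak of the compounds shown alone.

Compound 1 `COc1ccc(OCCOc2ccc3[nH]c(=O)n(C(C)C)c3c2)cc1`: 15.5% in an assay on cells for inhibition of Amine oxidase [flavin-containing] B (Homo sapiens), read by fluorescence, with stated times of 30 min and 15 min, tested at 1 uM; on this read-out lower numbers stand for less inhibition and higher numbers for more inhibition at the one concentration tested (going by the name of the read-out)
Compound 2 `CCn1c(=O)[nH]c2ccc(OCCOc3ccc(OC)cc3)cc21`: 13.9%
Compound 3 `Cc1ccc(COc2ccc3c(c2)C(C)(C)C(=O)N3)cc1`: reported as "not active" (no number reported), with no number

Compound 2 and compound 1 lie within the scatter of each other, as the step of a number 1.6 percentage points lower from compound 1 to compound 2 (within the scatter) shows. Compound 4 `CCn1c(=O)[nH]c2ccc(OCCOc3ccc(Cl)cc3)cc21` differs from compound 2 by chloro in place of methoxy on an aromatic carbon. Going by the values given here, no measured step covers this exchange; the only step available, a number 1.6 percentage points lower from compound 1 to compound 2 (within the scatter), concerns another part of the molecule and is itself within the scatter. Both measured numbers sit low, and nothing here points to a move in either direction, so no step beyond the scatter is expected: a number 0.1 percentage points higher from compound 2 to compound 4 (within the scatter). Compound 4 is therefore estimated at 14%, within 3% to 30%.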

Compound 4, a percentage reported as inhibition, at one concentration (the size of the read-out at that concentration, not a potency): 7.24%
Compound 4: middle estimate off by 6.8 percentage points, on the high side; measured number inside the range.
By their numbers in this assay, from the lowest: compounds 4, 2 and 1 (each within the scatter of the next).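

Going by these compounds alone, compound 2 and compound 4 give the first reading at this position: changing 4-methoxyphenyl to 4-chlorophenyl in this assay gives a number 6.7 percentage points lower from compound 2 to compound 4 (within the scatter). Chloro and methoxy therefore cannot be told apart here, even though chloro has one heavy atom and no hydrogen-bond acceptor, while methoxy has two heavy atoms and one acceptor. No measurement shown bears on the reason for this result.

Going by these compounds, whether any group at this position can move the number beyond the scatter remains open. How an amine or a carboxylic acid would read in this place is also unknown.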